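A few compounds are considered here, and "the series" means these few. Any claim that something is new, unique, unknown or untested is made for them only; others in the source may bear on it.

Measured so far in a functional assay on K562 cells (Homo sapiens) for inhibition, read by MTT assay, with a stated time of 48 h; a lower number here means a stronger inhibitor, a higher number a weaker inhibitor:
- compound 1 `Cc1ccc(NC(=O)c2cccc(C(F)(F)F)c2)cc1-n1cc(-c2cccnc2)cn1`: 270 nM
- compound 2 `Cc1ccc(NC(=O)c2ccc(C(F)(F)F)cc2)cc1-n1cc(-c2cccnc2)cn1`: 760 nM
- compound 3 `COc1ccc(C(=O)Nc2ccc(C)c(-n3cc(-c4cccnc4)cn3)c2)cc1`: 18300 nM

Compound 3 stands at the highest number of the three. Its nearest neighbour is compound 2, reached by a 24-fold higher number from compound 2 to compound 3 (1.38 log units; beyond the scatter); the furthest is compound 1, reached by a 68-fold higher number from compound 1 to compound 3 (1.83 log units; beyond the scatter). Both steps are large and beyond the scatter, so the acyl side of the shared core clearly moves this assay .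

Compound 4 `Cc1ccc(NC(=O)c2ccc(CN3CCCN(C)CC3)cc2)cc1-n1cc(-c2cccnc2)cn1` differs from compound 3 by (4-methyl-1,4-diazepan-1-yl)methyl in place of methoxy on an aromatic carbon. Within the data shown here, no measured step exchanges methoxy for a group of this kind, so the only steps that bear on the change are those at the same aromatic carbon and on the same acyl side: a 24-fold higher number from compound 2 to compound 3 (1.38 log units; beyond the scatter) and a 68-fold higher number from compound 1 to compound 3 (1.83 log units; beyond the scatter). Both show that a change at this position can shift the number by a large amount, and methoxy sits at the worst end of what has been measured. A step downward, beyond the scatter, is therefore expected for compound 4, on the order of a 31-fold lower number from compound 3 to compound 4 (1.48 log units; beyond the scatter). For compound 4 in this assay the estimate is 600 nM, with a range from 100 nM to 4000 nM.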

Compound 4, half-maximal inhibitory concentration: 8650 nM
Compound 4: middle estimate off by 14-fold (1.16 log units), on the low side; the whole stated range lies below it.
By their numbers in this assay, from the lowest: compound 1; then compound 2; then compound 4; then compound 3.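

At this aromatic carbon, para to a large group, replacing methoxy with the much larger (4-methyl-1,4-diazepan-1-yl)methyl group gives only a modest gain in this assay (a 2.1-fold lower number from compound 3 to compound 4 (0.33 log units; beyond the scatter)). The new group still falls well short of trifluoromethyl at the same carbon (an 11-fold higher number from compound 2 to compound 4 (1.06 log units; beyond the scatter)), so the order among these three groups is trifluoromethyl, then (4-methyl-1,4-diazepan-1-yl)methyl, then methoxy, and the added bulk and ring neither abolish activity nor restore the number seen with trifluoromethyl. No supporting data are available to explain this order.

Still open, going by these compounds, is whether a morpholine or a simple dimethylamino group on the same methylene link would track compound 4. Also open, on these data alone, is how the (4-methyl-1,4-diazepan-1-yl)methyl group would behave at the ring carbon that carries trifluoromethyl in compound 1.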